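Ethyl on the pendant phenyl of the dichlorostyryl lactone

The compounds below may be only part of what the source reports. "The series", "measured", "known", "first", "only" and "open" are said of these compounds alone.

Within the data shown here, compound 2 `O=C1C[C@H](O)C[C@@H](/C=C/c2c(Cl)cc(Cl)cc2-c2ccccc2)O1` gives 80 nM in an assay for inhibition of 3-hydroxy-3-methylglutaryl-coenzyme A reductase (Rattus norvegicus) (a higher number here means a weaker inhibitor, a lower number a stronger inhibitor), the highest of the two numbers so far. Among the measured compounds shown here, compound 1 `Cc1cc(F)ccc1-c1cc(Cl)cc(Cl)c1/C=C/[C@@H]1C[C@@H](O)CC(=O)O1` gives 36 nM, and the only step in hand is a 2.2-fold higher number from compound 1 to compound 2 (0.35 log units; beyond the scatter). Compound 3 `CCc1cccc(-c2cc(Cl)cc(Cl)c2/C=C/[C@@H]2C[C@@H](O)CC(=O)O2)c1` carries the change (ethyl in place of hydrogen on an aromatic carbon). That one step bears on it only loosely, since it covers substitution of the same phenyl but with different groups, and it lowered the number when the phenyl was substituted. A modest drop, at the edge of the scatter, is therefore expected for compound 3, about a 1.6-fold lower number from compound 2 to compound 3 (0.20 log units; within the scatter). Compound 3 is estimated at 50 nM, within 20 nM to 125 nM.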

Compound 3, half-maximal inhibitory concentration: 44 nM
Compound 3: the middle estimate sits 1.1-fold (0.06 log units) above what was measured, within the range that was stated.
By their numbers in this assay, from the lowest: compounds 1, 3 and 2 (each within the scatter of the next, the first and the last beyond it).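

In this assay, ethyl in place of hydrogen gives a 1.8-fold lower number from compound 2 to compound 3 (0.26 log units; within the scatter), so at this aromatic carbon, meta to a large group, ethyl and hydrogen cannot be separated. The other step, a 1.2-fold higher number from compound 1 to compound 3 (0.09 log units; within the scatter), likewise leaves 3-ethylphenyl and 4-fluoro-2-methylphenyl inseparable here, although compound 2 and compound 1 stand apart by more than the scatter. No measurement at hand accounts for these steps. Open, from the compounds shown here alone, is how an amine, a carboxylic acid or a longer chain at this same carbon would read, and whether ethyl elsewhere on this ring would match compound 3.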